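Cyclohexyl for tert-butyl on the amide-type nitrogen

A few compounds are considered here, and "the series" means these few. Any claim that something is new, unique, unknown or untested is made for them only; others in the source may bear on it.

Measured so far:
Compound 1, `C/C(=C\COC(=O)NC(C)(C)C)C1=CC(=O)C(C)(C)O1`, gives 4.1 ug/mL in a functional assay on L1210 cells (Mus musculus) for inhibition; a lower number here means a stronger inhibitor, a higher number a weaker inhibitor.
Compound 2, `C/C(=C\C=C/C1CCCCC1)C1=CC(=O)C(C)(C)O1`, gives 23 ug/mL in this assay.
Compound 3, `COc1ccc(/C=C/C=C(\C)C2=CC(=O)C(C)(C)O2)cc1`, gives 18 ug/mL in this assay.

Compound 1 holds the lowest number of the three. Its gap to compound 3 and its gap to compound 2 both lie beyond the usual scatter, so within this small set compound 1 is the strongest inhibitor. For the measured compounds named here, compounds 2 and 3 carry different chains on the shared core and give no single-point step to compound 1, so nothing can be read from them about the effect of one isolated change.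

Compound 4, `C/C(=C\COC(=O)NC1CCCCC1)C1=CC(=O)C(C)(C)O1`, is the next member and has not been measured. It differs from compound 1 in one place: cyclohexyl in place of tert-butyl on an amide-type nitrogen. Going by the values given here, no pair of measured compounds shows what this kind of exchange does in this assay. The step is expected to be small, in no clear direction, and not beyond the scatter. Compound 4 is expected to give 4.5 ug/mL, with a range from 1.5 ug/mL to 13 ug/mL. The step of a 1.1-fold higher number from compound 1 to compound 4 (0.04 log units; within the scatter) is estimated to stay within the scatter.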

Compound 4, half-maximal inhibitory concentration: 3.7 ug/mL
Compound 4: middle estimate off by 1.2-fold (0.09 log units), on the high side; measured number inside the range.
By their numbers in this assay, from the lowest: compounds 4 and 1 (each within the scatter of the next); then compounds 3 and 2 (each within the scatter of the next).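

For the compounds shown here, the exchange of tert-butyl for cyclohexyl on the amide-type nitrogen gives a 1.1-fold lower number from compound 1 to compound 4 (0.04 log units; within the scatter) in this assay, and this is the only single-place comparison in the set. At this position, then, the open-chain tert-butyl and the six-membered carbon ring give values that cannot be told apart, so the value of compound 1 does not depend on tert-butyl alone. Nothing at hand accounts for this equivalence.

The compounds shown hold only these two carbon groups on this nitrogen, so the reading may not extend to smaller or differently built groups such as methyl or phenyl. From the compounds shown here alone, whether a group carrying a carboxylic acid or an amine is accepted at this place also stays open.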